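A few compounds are considered here, and "the series" means these few. Any claim that something is new, unique, unknown or untested is made for them only; others in the source may bear on it.

Of the compounds shown here, three on one shared core have been measured so far in a functional assay on T-24 cells (Homo sapiens) for antiproliferative activity, read by sulforhodamine B assay, with a stated time of 72 h; on this read-out higher numbers stand for weaker inhibition and lower numbers for stronger inhibition. Compound 1 `CCCSc1ccc2c3c(cccc13)C1=NC(=O)C(C(=O)OCC)=C12` gives the lowest number (1700 nM), compound 2 `C=CCSc1ccc2c3c(cccc13)C1=NC(=O)C(C(=O)OCC(=O)SCCC)=C12` gives the highest (71800 nM), and compound 3 `C=CCOC(=O)C1=C2C(=NC1=O)c1cccc3c(SCC=C)ccc2c13` stands between them as second highest of the three (6600 nM). Compound 4 `C=CCSc1ccc2c3c(cccc13)C1=NC(=O)C(C(=O)OCC)=C12` has not yet been measured in this assay. It differs from compound 3 in one place (methyl in place of vinyl on a saturated chain carbon bound to an oxygen next to a carbonyl group), with methyl in place of vinyl on a saturated chain carbon bound to an oxygen next to a carbonyl group, so that allyloxycarbonyl becomes ethoxycarbonyl.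

For the measured compounds named here, only one measured step falls at this place (an 11-fold lower number from compound 2 to compound 3 (1.04 log units; beyond the scatter)). It is large and beyond the scatter, but it replaced (propylsulfanyl)carbonyl with vinyl, so it sets neither the size nor the direction of the present change. Ethoxycarbonyl also occurs in compound 1 (1700 nM), although that compound differs from compound 4 elsewhere as well. Its lower number gives a weak lean, and a modest move towards a lower number is expected (a 2.1-fold lower number from compound 3 to compound 4 (0.31 log units; beyond the scatter)). The estimated value for compound 4 is 3200 nM (expected range 1200 nM to 8000 nM).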

Compound 4, half-maximal inhibitory concentration: 700 nM
Beside the measured number, compound 4's estimate is 4.6-fold (0.66 log units) above it; measured number below the stated range.
By their numbers in this assay, from the lowest: compound 4; then compound 1; then compound 3; then compound 2.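

In this assay, the ester end proves sensitive even to a small exchange: methyl in place of vinyl on a saturated chain carbon bound to an oxygen next to a carbonyl group, which turns allyloxycarbonyl into ethoxycarbonyl, gives a 9.4-fold lower number from compound 3 to compound 4 (0.97 log units; beyond the scatter) and so separates two short ester groups clearly. Measured against the bulkier-named (propylsulfanyl)carbonyl end, the same place spans a 100-fold lower number from compound 2 to compound 4 (2.01 log units; beyond the scatter) in all, while the other place also counts, since vinyl in place of ethyl on a saturated chain carbon bound to a sulfur, with ethoxycarbonyl kept, gives a 2.4-fold lower number from compound 1 to compound 4 (0.39 log units; beyond the scatter) as a smaller step. Nothing available accounts for the size of these steps.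

What a carboxylic acid, an amide or a longer chain such as butyl would give on this carbonyl remains open, so the compounds shown do not say whether ethoxycarbonyl is a best point or only the lowest of three ends. On these data alone, it is also open whether the step at the sulfur chain would keep its direction with allyloxycarbonyl in place of ethoxycarbonyl.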